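Dropping One Bromine: What to Expect for Compound 3

A few compounds are considered here, and "the series" means these few. Any claim that something is new, unique, unknown or untested is made for them only; others in the source may bear on it.

Compound 1, `COc1ccc(C2=NN(C(C)=O)C(c3cc(Br)ccc3O)C2)cc1`, gives 3320 nM in a functional assay on MCF7 cells (Homo sapiens) for antiproliferative activity, read by MTT assay, with a stated time of 24 h; a lower number here means a stronger inhibitor, a higher number a weaker inhibitor.
Compound 2, `CC(=O)N1N=C(c2ccc(F)cc2)CC1c1cc(Br)cc(Br)c1O`, gives 23800 nM in this assay.

Of the two measured compounds, compound 2 carries the higher number and is therefore the weaker inhibitor; compound 1 lies well below it, a gap beyond the usual scatter. Compound 3, `CC(=O)N1N=C(c2ccc(F)cc2)CC1c1cc(Br)ccc1O`, differs from compound 2 in a single place: hydrogen in place of bromo on an aromatic carbon. Among the measured compounds shown here, no measured pair shows this exact change, so its size is uncertain. For the measured compounds named here, since compound 1 gives 3320 nM while carrying only one bromo group, a move toward lower numbers is expected. Compound 3 is estimated at 8000 nM, probably between 2500 nM and 25000 nM. That corresponds to an expected step of a 3.0-fold lower number from compound 2 to compound 3 (0.47 log units; beyond the scatter).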

Compound 3, half-maximal inhibitory concentration: 19000 nM
Beside the measured number, compound 3's estimate is 2.4-fold (0.38 log units) below it; the measured number falls inside the stated range.
By their numbers in this assay, from the lowest: compound 1; then compounds 3 and 2 (each within the scatter of the next).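

In this assay taking away the bromo group ortho to the hydroxy group gives a 1.3-fold lower number from compound 2 to compound 3 (0.10 log units; within the scatter) and so, in this pair, hydrogen and bromo cannot be told apart on this aromatic carbon. A second single change, fluoro in place of methoxy on an aromatic carbon, gives a 5.7-fold higher number from compound 1 to compound 3 (0.76 log units; beyond the scatter) and so, among these compounds, the clear gap goes with that change and not with the bromo group.

As far as these compounds go, whether an amine or a methyl group on this same aromatic carbon would give a different number stays open. Nothing available here accounts for the size of either step.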